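The source may report more compounds than this note shows. Statements on the series, on what has been measured and on what is new or still open speak of the compounds shown alone.

Measured so far in a functional assay on CHO cells for inhibition of Orexin/Hypocretin receptor type 1 (Homo sapiens), read by FLIPR and calcium flux; a lower number here means a stronger inhibitor, a higher number a weaker inhibitor:
- compound 1 `CCN(C(=O)CN(c1cc2c(C)nsc2cc1Cl)S(=O)(=O)c1ccc(OC)c(OC)c1)c1ccccn1`: 8 nM
- compound 2 `CCN(CC)C(=O)CN(c1cc2c(C)nsc2cc1Cl)S(=O)(=O)c1ccc(OC)c(OC)c1`: 29 nM
- compound 3 `CCN(CC)C(=O)CN(c1ccc(C)cc1)S(=O)(=O)c1ccc(OC(F)(F)F)cc1`: a limit of the assay, > 10000 nM

For the measured compounds named here, compound 2 holds the higher of the two numbers in this assay, with compound 1 nearest; the one measured step is a 3.6-fold higher number from compound 1 to compound 2 (0.56 log units; beyond the scatter), a change on the amide-type nitrogen. Compound 4 `CCN(CC)C(=O)CN(c1ccc(C)cc1)S(=O)(=O)c1ccc(OC)c(OC)c1` is not yet measured. It differs from compound 2 as follows: a group of 7 heavy atoms (7 carbon; one six-membered aromatic ring of carbon only) in place of a group of 11 heavy atoms (8 carbon, 1 nitrogen, 1 sulfur, 1 chlorine; one five-membered aromatic ring with 2 hetero atoms, one six-membered aromatic ring of carbon only), on a sulfonamide nitrogen. Going by the values given here, no measured step touches the sulfonamide nitrogen, so none bears directly on this change. What is known of the 4-methylphenyl group on that nitrogen is compound 3, which carries it with a different sulfonyl aryl and sits at the limit of > 10000 nM in this assay, at which 1 of the 3 values shown sits. Against that background a large step upward is expected, though the size is uncertain because compound 3 differs from compound 4 in the sulfonyl aryl as well. The expected step is a 69-fold higher number from compound 2 to compound 4 (1.84 log units; beyond the scatter). Compound 4 is therefore estimated at 2000 nM, with a range from 300 nM to 10000 nM in this assay.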

Compound 4, half-maximal inhibitory concentration: > 10000 nM
Compound 4: no number, only a limit; the forecaster's own chance of this, stated with the estimate: 30%; at least 5.0-fold (0.69 log units) between middle value and limit.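

In this assay, 4-methylphenyl in place of the larger group on the sulfonamide nitrogen gives an at least 340-fold higher number from compound 2 to compound 4 (2.53 log units; beyond the scatter), a larger step than the one on the amide-type nitrogen, a 3.6-fold higher number from compound 1 to compound 2 (0.56 log units; beyond the scatter). Compound 4 sits at a limit of the assay, > 10000 nM, and it keeps the sulfonyl aryl of compound 2, so the loss belongs to this one change. Compound 3 carries the same 4-methylphenyl with a different sulfonyl aryl, and no order can be read between it and compound 4: the limit of > 10000 nM in this assay, at which 2 of the 4 values shown sit.

Still open, on these data alone, is which part of the group that left is needed: the chlorine, the methyl or the five-membered aromatic ring, all of which went in a single change. A 4-chlorophenyl group on the sulfonamide nitrogen would test the chlorine apart from the five-membered ring.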